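Swapping Amino for Hydroxy on a Urea Aryl Ring

The source may hold more compounds than are shown below. What is called first, only, known or untested is meant among the compounds shown, and "the series" means these compounds.

Compound 1 `COc1ccc(NC(=O)Nc2cc(C)nc3ccccc23)cc1F`: 2700 nM
Compound 2 `Cc1cc(NC(=O)Nc2ccc(N)cc2)c2ccccc2n1`: 18500 nM

In a physicochemical assay for solubility, at pH 7.4 (a higher number here means a more soluble compound, a lower number a less soluble compound), compound 2 gives the higher of the two numbers, and its gap to compound 1 lies beyond the usual scatter. Compound 3 `Cc1cc(NC(=O)Nc2ccc(O)cc2)c2ccccc2n1` differs from compound 2 in one place: hydroxy in place of amino on an aromatic carbon. Among the compounds with values here, no measured pair shows this exchange, so only a small step is expected, likely a slight loss in solubility or nothing beyond the scatter. The expected step is a 1.5-fold lower number from compound 2 to compound 3 (0.19 log units; within the scatter). For compound 3 a solubility of 12000 nM is estimated, in a range from 5000 nM to 30000 nM.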

Compound 3, solubility: 100 nM
For compound 3 the middle estimate is 120-fold (2.08 log units) above the measured one, and the stated range ends above it.
By their numbers in this assay, from the lowest: compound 3; then compound 1; then compound 2.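

In this assay the exchange on an aromatic carbon para to a large group gives a 190-fold lower number from compound 2 to compound 3 (2.27 log units; beyond the scatter) and so shows that amino and hydroxy are far from interchangeable in this place. The two groups match in heavy atoms, hydrogen-bond donors, hydrogen-bond acceptors and net charge, so these counts alone do not tell them apart here. Nothing at hand accounts for the size of this step. Still open, from the compounds shown here alone, is whether a dimethylamino group or a carboxylic acid in the same place would give a number nearer that of compound 2 or that of compound 3.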